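This account rests on a few compounds, and the source may have more. Where it says the series, first, only, none or still open, it means among the compounds named here.

Working notes on the series. Compound 1 `COc1cc(C(=O)NS(=O)(=O)c2ccccc2OC)ccc1Cn1ccc2ccc(NC(=O)CC3CCCC3)cc21` in a functional assay (trachea) for antagonist activity, with Cavia porcellus as the target (on this read-out higher numbers stand for higher potency (the scale is a negative logarithm) and lower numbers for lower potency), gives 9.7, the second highest of the three numbers recorded. Compound 2 `COC(=O)C(C(=O)c1ccc(Cn2ncc3ccc(NC(=O)OC4CCCC4)cc32)c(OC)c1)S(=O)(=O)c1ccccc1` gives 9.9, which lies within the scatter of compound 1. Compound 3 `CCCCOC(=O)Nc1ccc2cnn(Cc3ccc(-c4nn[nH]n4)cc3OC)c2c1` gives 7.1, well below compound 1 and beyond the scatter. No pair among these three differs in only one place, so no single-point step is available as a guide.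

Compound 4 `COc1cc(C(=O)NS(=O)(=O)c2c(C)cccc2Cl)ccc1Cn1ccc2ccc(NC(=O)CC3CCCC3)cc21` is not yet measured. It differs from compound 1 by 2-chloro-6-methylphenyl in place of 2-methoxyphenyl on a sulfonyl sulfur. Within the data shown here, with no comparable step recorded, only a modest change is expected, in either direction, most likely none beyond the scatter. Compound 4 is accordingly estimated at 9.5 in this assay, within a range from 8.8 to 10.2, an expected step of a number 0.20 log units lower from compound 1 to compound 4 (within the scatter).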

Compound 4, negative logarithm of the antagonist equilibrium constant: 8.8
For compound 4 the middle estimate is 0.70 log units above the measured one, and the stated range covers the measured number.
By their numbers in this assay, from the lowest: compound 3; then compound 4; then compounds 1 and 2 (each within the scatter of the next).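

Among these compounds, at the sulfonyl sulfur, the aryl group is not a silent place in this assay: 2-chloro-6-methylphenyl in place of 2-methoxyphenyl gives a number 0.90 log units lower from compound 1 to compound 4 (beyond the scatter) as the first single-place step. The change keeps the heavy-atom count and gives up the one hydrogen-bond acceptor of the leaving group, yet the core of compound 1 is untouched. No measurement at hand bears on the reason for this step.

The compounds shown leave open whether the chlorine, the methyl or the loss of the methoxy carries the step. From the compounds shown here alone, how a plain phenyl or a 2-methylphenyl on the same sulfur would read also remains open.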